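Trimming the Linker Chain: From Compound 1 to Compound 4

This account rests on a few compounds, and the source may have more. Where it says the series, first, only, none or still open, it means among the compounds named here.

Measured so far:
- Compound 1, `Cn1c(Cc2nn(C)c(=O)c3ccccc23)nnc1SCCCCCCCCCCC(=O)Nc1ccc(Cl)cc1Cl`: 3300 nM
- Compound 2, `Cn1c(Cc2nn(C)c(=O)c3ccccc23)nnc1SCCCCCCCC(=O)Oc1ccc(Cl)cc1Cl`: 800 nM
- Compound 3, `COc1ccc(NC(=O)CSc2nnc(Cc3nn(C)c(=O)c4ccccc34)n2C)cc1`: "not active" (no number reported)

Three compounds share the same core and differ in the tether that joins it to a substituted phenyl ring. In an assay on isolated protein (Mus musculus) for inhibition of IL15-IL15 receptor (Homo sapiens), read by resazurin assay, with stated times of 30 min and 2.5 days (on this read-out lower numbers stand for stronger inhibition and higher numbers for weaker inhibition), compound 1 gives 3300 nM, the highest of the two numbers recorded. Compound 2, which carries a shorter chain ending in an ester rather than an amide, gives 800 nM in this assay, and that gap to compound 1 lies beyond the usual scatter. Compound 3, with only a very short tether, gave no measurable number.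

Compound 4, `Cn1c(Cc2nn(C)c(=O)c3ccccc23)nnc1SCCCCCCCCCC(=O)Nc1ccc(Cl)cc1Cl`, has not yet been measured. It differs from compound 1 in one place: (2,4-dichlorophenyl)carbamoyl in place of ((2,4-dichlorophenyl)carbamoyl)methyl on a saturated chain carbon, nine bonds along the chain from a sulfur. In plain terms the chain is shorter by a single carbon while the amide and the dichlorophenyl ring stay as they are. Going by the values given here, no step between two measured compounds covers such a small change in chain length on its own, so the shift in this assay can only be guessed from compound 2 and compound 1. A chain trimmed by one carbon is expected to leave the number close to that of compound 1, and the step of a 1.3-fold lower number from compound 1 to compound 4 (0.12 log units; within the scatter) is estimated to stay within the scatter. Compound 4 is therefore expected to give about 2500 nM, with a likely range from 1000 nM to 6000 nM.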

Compound 4, half-maximal inhibitory concentration: 2300 nM
Compound 4: the middle estimate sits 1.1-fold (0.04 log units) above what was measured; low and high end bracket the measured number.
By their numbers in this assay, from the lowest: compound 2; then compounds 4 and 1 (each within the scatter of the next).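

In this assay, putting (2,4-dichlorophenyl)carbamoyl in place of ((2,4-dichlorophenyl)carbamoyl)methyl gives a 1.4-fold lower number from compound 1 to compound 4 (0.16 log units; within the scatter) and so does not shift the number beyond the usual scatter. Going by these compounds alone, this is the first step between measured compounds that changes only the chain length, with the amide and the dichlorophenyl ring left as they are, and it shows that this small trim on a saturated chain carbon, nine bonds along the chain from a sulfur, leaves the read-out in the same range, so compound 1 and compound 4 cannot be told apart here. No measurement at hand says why the number holds across this change.

From the compounds shown here alone, one pair cannot show how far the chain can be changed, so it remains open whether a much shorter chain or a longer chain on the same amide would keep the number in this range. Also open, going by these compounds, is what a single change at the chain's far end would do to compound 4, such as an ester or a carboxylic acid in place of the amide.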